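A few compounds are considered here, and "the series" means these few. Any claim that something is new, unique, unknown or untested is made for them only; others in the source may bear on it.

Compound 1 `ClCc1ccccc1Cn1cnc2c(Cl)nc(Cl)nc21` and compound 2 `ClCc1cccc(Cn2cnc3c(Cl)nc(Cl)nc32)c1` share the same atoms joined differently; the difference between the two cores is not broken down here. In a functional assay on NCI/ADR-RES cells (Homo sapiens) for cytotoxicity, read by sulforhodamine B assay, with a stated time of 48 h (on this read-out higher numbers stand for weaker inhibition of growth and lower numbers for stronger inhibition of growth), compound 1 gives 3020 nM, while compound 2 gives 5240 nM, and the two values lie within the usual scatter of each other. Compound 3 `Nc1nc(Cl)c2ncn(Cc3ccccc3CCl)c2n1` carries the change amino in place of chloro on an aromatic carbon on the core of compound 1, and in this assay compound 3 gives 34700 nM. That change made a step of an 11-fold higher number from compound 1 to compound 3 (1.06 log units; beyond the scatter), a large weakening of growth inhibition.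

Compound 4 `Nc1nc(Cl)c2ncn(Cc3cccc(CCl)c3)c2n1` carries the same change, (amino in place of chloro on an aromatic carbon), on the core of compound 2, at the same kind of place. Its value in this assay is not yet known. For the measured compounds named here, because the one measured step with this change, an 11-fold higher number from compound 1 to compound 3 (1.06 log units; beyond the scatter), was large, compound 4 is expected to show a step of about a 10-fold higher number from compound 2 to compound 4 (1.02 log units; beyond the scatter) from compound 2. On that basis compound 4 is estimated at 55000 nM in this assay, with a likely range from 20000 nM to 150000 nM.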

Compound 4, concentration for total growth inhibition: 20000 nM
Estimate against measurement, compound 4: 2.8-fold (0.44 log units) above; the measured number falls inside the stated range.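

In this assay, amino in place of chloro on an aromatic carbon again gives weaker inhibition of growth, with a 3.8-fold higher number from compound 2 to compound 4 (0.58 log units; beyond the scatter), so the direction of the change holds on both cores. For the compounds shown here, the size of the step does not carry over, and the two steps differ by more than the scatter: the same change on two cores in this assay, an 11-fold higher number (1.06 log units; beyond the scatter) from compound 1 to compound 3 and a 3.8-fold higher number (0.58 log units; beyond the scatter) from compound 2 to compound 4, 3.0-fold (0.48 log units) apart, beyond the scatter of two such steps These two pairs show only that the step depends on the core to some degree; they do not show what in the cores sets the size of the step, nor how the change would behave on any third core.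

The compounds shown leave open how other groups on the same aromatic carbon, such as a methoxy group or a dimethylamino group, would compare with chloro and amino. They also leave open whether the step would keep its size if the remaining chloro group gave way to a methyl group.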